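The compounds below may be only part of what the source reports. "The series", "measured", "known", "first", "only" and "open" are said of these compounds alone.

Working notes on the series.

Three analogues sharing one core have been run in a functional assay on PBMC cells (Homo sapiens) for inhibition, read by ELISA, with a stated time of 18 h; a higher number here means a weaker inhibitor, a lower number a stronger inhibitor. Compound 1 `CC1(C)CC(=O)C(C(=S)SCc2ccccc2)=C(Nc2ccc(Cl)cc2Cl)C1` gives only a limit in this assay, > 20 ug/mL. Compound 2 `CC1(C)CC(=O)C(C(=S)SCCO)=C(Nc2ccc(Cl)cc2Cl)C1` likewise returns a limit in this assay, > 20 ug/mL. Compound 3 `CC1(C)CC(=O)C(C(=S)SCc2ccccc2)=C(Nc2ccc(Cl)cc2)C1` also sits at a limit in this assay, > 20 ug/mL. The step from compound 1 to compound 2, a step that the two limits leave unreadable from compound 1 to compound 2, is hydroxymethyl in place of phenyl on a saturated chain carbon bound to a sulfur. The step from compound 1 to compound 3, a step that the two limits leave unreadable from compound 1 to compound 3, is hydrogen in place of chloro on an aromatic carbon. All three values lie at the same point, (the limit of > 20 ug/mL in this assay, at which 3 of the 3 values shown sit), so no size can be read for either step.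

Compound 4 `CC1(C)CC(=O)C(C(=S)SCCO)=C(Nc2ccc(Cl)cc2)C1` is not yet measured in this assay. It differs from compound 3 by hydroxymethyl in place of phenyl on a saturated chain carbon bound to a sulfur, the same kind of change that separates compound 1 from compound 2; the two cores differ as described in hydrogen in place of chloro on an aromatic carbon. The earlier instance of this change, from compound 1 to compound 2, left both values at the limit, so the step it made is not readable. For compound 4 the expected step from compound 3 is a step that the limit leaves unreadable from compound 3 to compound 4, resting on compound 3 at > 20 ug/mL and on the unreadable earlier step. Compound 4 is therefore estimated at 30 ug/mL, with a range from 12 ug/mL to 80 ug/mL, and most likely only a limit will again be reported.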

Compound 4, half-maximal inhibitory concentration: > 20 ug/mL
Compound 4 ended at the assay's limit; the forecaster's own chance of this, stated with the estimate: 85%; the middle value does not contradict the limit.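

Compound 4 gives only a limit in this assay, > 20 ug/mL. No size can be read for the steps joining compound 4 to compound 3 and to compound 2, with every value resting at the same point: the limit of > 20 ug/mL in this assay, at which 4 of the 4 values shown sit.

The compounds shown leave open whether either change affects inhibition in this assay, since none of the four yields a number.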